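The compounds below may be only part of what the source reports. "The series", "measured", "known", "first", "only" and "open" are said of these compounds alone.

Of the compounds shown here, three sharing one core have been measured in a functional assay on IMR-32 cells with melanin-concentrating hormone receptor 1 (Homo sapiens) as the target, read by fluorescence; on this read-out lower numbers stand for stronger inhibition and higher numbers for weaker inhibition. Compound 1 `CC(CNCC1CC1)Oc1cccc2ccc(N)nc12` gives 460 nM. Compound 2 `CC(CNC1CC1)Oc1cccc2ccc(N)nc12`, with cyclopropyl in place of cyclopropylmethyl on the amine nitrogen, gives 580 nM. Compound 3 `CC(CNCc1ccccc1)Oc1cccc2ccc(N)nc12`, with phenyl in place of cyclopropyl on the saturated chain carbon bound to the amine nitrogen, gives 340 nM. Compound 3 has the lowest of the three numbers, but the steps are small: a 1.4-fold lower number from compound 1 to compound 3 (0.13 log units; within the scatter) and a 1.7-fold lower number from compound 2 to compound 3 (0.23 log units; within the scatter), and also a 1.3-fold higher number from compound 1 to compound 2 (0.10 log units; within the scatter). None of the three substituents on or near the amine nitrogen moves the number beyond the scatter.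

Compound 4 `CC(CNCc1ccoc1)Oc1cccc2ccc(N)nc12` carries the change (furan-3-yl in place of phenyl on a saturated chain carbon bound to an amine nitrogen). Going by the values given here, no measured step swaps one aromatic ring for another at this position, so the nearest guide is that the group on this side of the amine nitrogen has so far been tolerant of exchange between cyclopropylmethyl, cyclopropyl and benzyl without a step beyond the scatter. On that basis the step from compound 3 to compound 4 in this assay is expected to be small, a 1.2-fold higher number from compound 3 to compound 4 (0.09 log units; within the scatter), in no firm direction. Compound 4 is therefore estimated at 420 nM, with a range from 200 nM to 900 nM.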

Compound 4, half-maximal inhibitory concentration: 100 nM
Beside the measured number, compound 4's estimate is 4.2-fold (0.62 log units) above it; measured number below the stated range.
By their numbers in this assay, from the lowest: compound 4; then compounds 3, 1 and 2 (each within the scatter of the next).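

In this assay, going by these compounds alone, this is the first change to move the number beyond the scatter: furan-3-yl in place of phenyl on a saturated chain carbon bound to an amine nitrogen gives a 3.4-fold lower number from compound 3 to compound 4 (0.53 log units; beyond the scatter) and shows that this position is not indifferent to which aromatic ring it carries. Compound 4 also stands apart from the two compounds with cyclopropyl groups, with a 4.6-fold lower number from compound 1 to compound 4 (0.66 log units; beyond the scatter) and a 5.8-fold lower number from compound 2 to compound 4 (0.76 log units; beyond the scatter), whereas compounds 1, 2 and 3 all lie within the scatter of one another. Nothing given here accounts for this difference.

The swap alters the ring size and brings in an oxygen atom in a single step, so the compounds shown leave open which of these two differences matters, a question that thiophen-3-yl, with sulfur in the same five-membered ring, or pyridin-3-yl, with nitrogen in a six-membered ring, could help to answer. They also leave open whether furan-2-yl would give a similar number, and whether a methyl group on the furan ring or a longer chain leading to it would keep the lower number of compound 4.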